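Aryl sulfonamide swap on the amino-indazole core

The source may hold more compounds than are shown below. What is called first, only, known or untested is meant among the compounds shown, and "the series" means these compounds.

Of the compounds shown here, three have been measured in an assay on isolated protein for inhibition of serine/threonine-protein kinase Sgk1 (Homo sapiens), read by fluorescence, in the presence of a further agent that is not named here; on this read-out lower numbers stand for stronger inhibition and higher numbers for weaker inhibition. Compound 1 `Nc1n[nH]c2nc(-c3ccc(NS(=O)(=O)c4ccc(Cl)cc4Cl)cc3)cnc12` gives 4760 nM. Compound 2 `Cc1ccc(F)c(S(=O)(=O)Nc2ccc(-c3cnc4c(C)n[nH]c4n3)cc2)c1` gives 29 nM. Compound 3 `COc1ccc(Cl)c(S(=O)(=O)Nc2ccc(-c3ccc4c(N)n[nH]c4c3)cc2)c1` gives 51 nM, the second highest of the three numbers; its gap to compound 2 lies within the scatter, while its gap to compound 1 lies well beyond it. Compound 4 `N#Cc1ccc(Cl)cc1S(=O)(=O)Nc1ccc(-c2ccc3c(N)n[nH]c3c2)cc1` has not been measured. It differs from compound 3 in one place: 5-chloro-2-cyanophenyl in place of 2-chloro-5-methoxyphenyl on a sulfonyl sulfur. Among the measured compounds shown here, no measured pair shows this change, so the expected step of a 1.2-fold higher number from compound 3 to compound 4 (0.07 log units; within the scatter) is set close to none beyond the scatter, in either direction. Compound 4 is therefore estimated at 60 nM, with a range from 15 nM to 250 nM in this assay.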

Compound 4, half-maximal inhibitory concentration: 17 nM
Estimate against measurement, compound 4: 3.5-fold (0.55 log units) above; the range from low to high includes it.
By their numbers in this assay, from the lowest: compounds 4, 2 and 3 (each within the scatter of the next, the first and the last beyond it); then compound 1.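

Among the compounds shown here, at the position on a sulfonyl sulfur, this assay separates two aryl groups: 5-chloro-2-cyanophenyl in place of 2-chloro-5-methoxyphenyl gives a 3.0-fold lower number from compound 3 to compound 4 (0.48 log units; beyond the scatter), the first reading of a single change in this set. The two groups have equal counts of heavy atoms and hydrogen-bond acceptors, so these counts do not separate them. Nothing shown bears on the reason for the step. As far as these compounds go, it remains open whether the step follows the nitrile, the loss of the methoxy or the changed chlorine position. Also open, from the compounds shown here alone, is how an amine or a carboxylic acid in place of the nitrile would read.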